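Swapping the chloromethyl of compound 2 for a vinyl group

The compounds below may be only part of what the source reports. "The series", "measured", "known", "first", "only" and "open" are said of these compounds alone.

Measured so far:
compound 1 `O=C(NCCCCl)Nc1ccc(I)cc1` — 90000 nM
compound 2 `CCCCC(OC)c1cccc(NC(=O)CCl)c1` — 13000 nM
compound 3 `CC(C)(C)c1ccc(CNC(=O)CCCCl)cc1` — 72000 nM

All three compounds were tested in a functional assay on HT-29 cells (Homo sapiens) for antiproliferative activity, with a stated time of 48 h; on this read-out lower numbers stand for stronger inhibition and higher numbers for weaker inhibition. Compound 2 holds the lowest number of the three, and its distance to the nearest of the others, compound 3, as well as to the furthest, compound 1, lies beyond the usual scatter, so compound 2 is the most potent of this small set.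

The next compound, compound 4 `C=CC(=O)Nc1cccc(C(CCCC)OC)c1`, has not been measured yet. It differs from compound 2 in one place: vinyl in place of chloromethyl on a carbonyl carbon. The rest of the molecule, the aromatic core with its methoxy-bearing side chain and the amide-type nitrogen, is kept as it is.

Within the data shown here, no pair of measured compounds shows this particular change, so the data give no direct yardstick for its size. The expectation is a moderate shift toward a higher number in this assay, that is, toward weaker inhibition, while staying closer to compound 2 than to compound 1 or compound 3. For compound 4 the estimated value is 30000 nM, within a range from 8000 nM to 100000 nM, which is an expected step of a 2.3-fold higher number from compound 2 to compound 4 (0.36 log units; beyond the scatter).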

Compound 4, half-maximal inhibitory concentration: 40000 nM
Compound 4: middle estimate off by 1.3-fold (0.12 log units), on the low side, and the stated range covers the measured number.
By their numbers in this assay, from the lowest: compound 2; then compounds 4, 3 and 1 (each within the scatter of the next, the first and the last beyond it).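

In this assay, among these compounds, the swap of chloromethyl for vinyl on the carbonyl carbon gives a 3.1-fold higher number from compound 2 to compound 4 (0.49 log units; beyond the scatter) and is the first change in this set that can be read at a single place, with the rest of the molecule held constant. The step is modest, yet it lies beyond the usual scatter of repeated measurements, so this position does respond to what is attached there, and of these two compounds, the one carrying chloromethyl is the stronger inhibitor. No measurement at hand accounts for the step, so it remains an observation about this one pair of compounds.

The compounds shown leave open whether other groups on the same carbonyl carbon, such as a plain methyl, an ethynyl or a longer chloroalkyl chain, would stay close to compound 2 or fall further away. They also leave open whether this swap would produce a step of similar size on a different core, since a single pair cannot show how far the result carries.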